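Moving the chlorine: from compound 3 to compound 4

The source may report more compounds than this note shows. Statements on the series, on what has been measured and on what is new or still open speak of the compounds shown alone.

In a functional assay on OVCAR-3 cells (Homo sapiens) for cytotoxicity, read by sulforhodamine B assay (on this read-out lower numbers stand for higher toxicity in this test and higher numbers for lower toxicity in this test), compound 1 `COc1ccc(/C=N\NC(=S)NC(C)(C)CCC[C@](C)(O)[C@@H]2CC=C(C)CC2)cc1`, which carries a 4-methoxyphenyl group, gives a true number, 46200 nM. Compound 2 `CC1=CC[C@@H]([C@@](C)(O)CCCC(C)(C)NC(=S)N/N=C\c2ccc(N(C)C)cc2)CC1` gives only a limit, > 100000 nM. Compound 3 `CC1=CC[C@@H]([C@@](C)(O)CCCC(C)(C)NC(=S)N/N=C\c2ccccc2Cl)CC1` also gives only a limit, > 100000 nM, and so stands at the limit of > 100000 nM in this assay, at which 2 of the 3 values shown sit. As far as these compounds go, its exact value is unknown.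

Compound 4 `CC1=CC[C@@H]([C@@](C)(O)CCCC(C)(C)NC(=S)N/N=C\c2ccc(Cl)cc2)CC1` has the same atoms, joined differently: 4-chlorophenyl in place of 2-chlorophenyl on a carbon with a double bond to nitrogen. In short, 4-chlorophenyl stands in place of 2-chlorophenyl on a carbon with a double bond to nitrogen.

Within the data shown here, three measured steps bear on this change, although none of them moves a chlorine. Exchanging the whole group gave an at least 2.1-fold higher number from compound 1 to compound 3 (0.33 log units; beyond the scatter), and exchanging methoxy for dimethylamino gave an at least 2.1-fold higher number from compound 1 to compound 2 (0.33 log units; beyond the scatter). From the compounds shown here alone, both are at least modest, but both end at a limit, so their true size stays open. The third, a step that the two limits leave unreadable from compound 2 to compound 3, cannot be sized at all.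

Among the measured compounds shown here, compound 1 with 46200 nM holds the only true number. Compound 4 is expected to lie near the limit, with no step beyond the scatter in this assay. The expected step is an at least 1.1-fold lower number from compound 3 to compound 4 (0.04 log units; that floor lies within the scatter). For compound 4 the estimated value is 90000 nM, with an expected range from 40000 nM to 150000 nM.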

Compound 4, concentration lethal to 50% of the cells: 40600 nM
Compound 4: middle estimate off by 2.2-fold (0.35 log units), on the high side; measured number inside the range.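

In this assay, where the chlorine sits turns out to matter: with the same atoms in both compounds, 4-chlorophenyl in place of 2-chlorophenyl gives an at least 2.4-fold lower number from compound 3 to compound 4 (0.39 log units; beyond the scatter), so the higher toxicity in this test is tied to the arrangement and not to the presence of chlorine alone. Chloro in place of dimethylamino on the aromatic carbon gives an at least 2.4-fold lower number from compound 2 to compound 4 (0.39 log units; beyond the scatter), while chloro in place of methoxy gives a 1.1-fold lower number from compound 1 to compound 4 (0.06 log units; within the scatter), so chloro and methoxy cannot be told apart here, and the dimethylamino compound is the one that stands apart among these three groups. The first two of these steps start from a value that is only a limit, so they give a minimum and not a full size: the limit of > 100000 nM in this assay, at which 2 of the 4 values shown sit.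

The compounds shown do not reveal whether another group, such as bromo or a nitrile, would respond in the same way to a change of place on the aromatic ring. They also leave open what an amine or a carboxylic acid in place of chloro would do to this toxicity.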